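The source may report more compounds than this note shows. Statements on the series, on what has been measured and on what is new or still open speak of the compounds shown alone.

Measured so far:
compound 1, `COc1ccc(COC[C@@H]2CCc3cc([C@H]4CC[C@](N)(CO)C4)ccc3C2)cc1`: 33% in a functional assay on the whole organism (strain Lewis) with Rattus norvegicus as the target, with a stated time of 24 h, at a dose of 0.3 mg/kg by the oral route; on this read-out higher numbers stand for more inhibition at the one dose given (going by the name of the read-out) and lower numbers for less inhibition
compound 2, `COc1cccc(CO[C@H]2CCc3cc([C@H]4CC[C@](N)(CO)C4)ccc3C2)c1`: 13% in this assay

Within the data shown here, compound 2 stands at the lower of the two numbers in this assay; the only other value, that of compound 1, lies higher by an amount beyond the usual scatter. Among the measured compounds shown here, compound 3 is `COc1cccc(CO[C@@H]2CCc3cc([C@H]4CC[C@](N)(CO)C4)ccc3C2)c1`. the two compounds have the same atoms and bonds and differ only in configuration as drawn: 1 of 3 stereo elements differ; a stereocentre at a saturated ring carbon is drawn S in compound 2 and R in compound 3 No step between two measured compounds is available, and compound 1 differs from compound 2 in more than one place, so the two measured values alone give no guide to what a change of configuration at one centre does in this assay. Such a change could raise or lower the inhibition, or leave it within the scatter. With nothing pointing one way, compound 3 is expected to come out in this assay near compound 2, with a wide range: 20%, between 5% and 45%. The estimated step is a number 7 percentage points higher from compound 2 to compound 3 (within the scatter).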

Compound 3, a percentage reported as inhibition, in the whole organism at one dose (the size of the read-out at that dose, not a potency): 15%
Beside the measured number, compound 3's estimate is 5 percentage points above it, and the stated range covers the measured number.
By their numbers in this assay, from the lowest: compounds 2 and 3 (each within the scatter of the next); then compound 1.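

Setting the saturated ring carbon as R rather than S gives, in this assay, a number 2 percentage points higher from compound 2 to compound 3 (within the scatter). At this single dose, the configuration at this carbon therefore has no effect that can be told apart from the scatter, which the earlier values could not show, as compound 1 differs from compound 2 in more than one place. The comparison isolates this one centre: the fact that compounds 2 and 3 differ only in the configuration as drawn

The compounds shown leave open whether the same holds at other doses or at the other stereo elements, since a single dose can hide a difference in potency. They also leave open how the inhibition would respond if an amine, a carboxylic acid or a longer chain such as ethoxy stood in place of the methoxy group.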